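A smaller aryl group on the shared core

This account rests on a few compounds, and the source may have more. Where it says the series, first, only, none or still open, it means among the compounds named here.

Within the data shown here, compound 2 `Clc1ccc(CO/N=C/c2c(-c3cccc4ccccc34)nc3sccn23)cc1Cl` gives 940 nM in an assay on HepG2 cells for agonist activity at nuclear receptor subfamily 1 group I member 3 (Homo sapiens), read by a luciferase reporter, with a stated time of 23 h (a lower number here means that less compound is needed, a higher number that more compound is needed for the effect), the lower of the two numbers known so far. Compound 1 `CC(C)(C)c1ccc(CO/N=C/c2c(-c3ccc4ccccc4c3)nc3occn23)cc1` gives 7900 nM in this assay, a higher number beyond the usual scatter, but it differs from compound 2 in several places at once. Compound 3 `CC(C)c1ccc(-c2nc3sccn3c2/C=N/OCc2ccc(Cl)c(Cl)c2)cc1` carries 4-isopropylphenyl in place of naphthalen-1-yl on an aromatic carbon. Among the measured compounds shown here, no single-change step between measured compounds exists to guide this, so the expected step of a 2.1-fold higher number from compound 2 to compound 3 (0.33 log units; beyond the scatter) is only a modest rise. Compound 3 is therefore estimated at 2000 nM, with a range from 600 nM to 6500 nM.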

Compound 3, half-maximal effective concentration: 590 nM
Compound 3: the middle estimate sits 3.4-fold (0.53 log units) above what was measured, outside the stated range (below it).
By their numbers in this assay, from the lowest: compounds 3 and 2 (each within the scatter of the next); then compound 1.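

In this assay, among these compounds, the step of a 1.6-fold lower number from compound 2 to compound 3 (0.20 log units; within the scatter) is the first single change that can be read at this position. On this aromatic carbon of the shared core, 4-isopropylphenyl, with one six-membered aromatic ring, takes the place of naphthalen-1-yl, with two, without a difference beyond the scatter. No evidence on the cause is at hand. The compounds shown leave open whether plain phenyl, without the isopropyl group, would give a similar number. They also leave open how an amine, a carboxylic acid or a longer chain in place of that isopropyl group would read.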